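This account rests on a few compounds, and the source may have more. Where it says the series, first, only, none or still open, it means among the compounds named here.

Measured compounds:
Compound 1, `CCCCCCCCn1cc(COC2(C(F)(F)F)Oc3ccccc3C=C2C(=O)OCC)nn1` — in a functional assay on HeLa cells (Homo sapiens) for inhibition, read by MTT assay, with a stated time of 24 h (on this read-out higher numbers stand for weaker inhibition and lower numbers for stronger inhibition), compound 1 reaches only the limit > 150000 nM.
Compound 2, `CCOC(=O)C1=Cc2ccccc2OC1(OCc1cn(-c2ccc(F)c(Cl)c2)nn1)C(F)(F)F` — in this assay compound 2 gives 22700 nM.
Compound 3, `CCOC(=O)C1=Cc2ccccc2OC1(OCc1cn(-c2cccc(C(F)(F)F)c2)nn1)C(F)(F)F` — in this assay compound 3 reaches only the limit > 150000 nM.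

Compound 3 therefore stands at the edge of what this assay can report, sharing that position with compound 1 (the limit of > 150000 nM in this assay, at which 2 of the 3 values shown sit), while compound 2 alone gives a number. Compound 4, `CCOC(=O)C1=Cc2ccccc2OC1(OCc1cn(CC(=O)Nc2cccc(Cl)c2)nn1)C(F)(F)F`, differs from compound 3 in one place: ((3-chlorophenyl)carbamoyl)methyl in place of 3-(trifluoromethyl)phenyl on an aromatic nitrogen.

For the measured compounds named here, three measured steps bear on this change, all on the same aromatic nitrogen. The step of an at least 6.6-fold higher number from compound 2 to compound 3 (0.82 log units; beyond the scatter) shows that a chlorine-bearing aryl group outperforms the trifluoromethyl aryl by at least a modest margin. The step of an at least 6.6-fold lower number from compound 1 to compound 2 (0.82 log units; beyond the scatter) shows the same chlorine-bearing aryl outperforming an octyl chain. The step that the two limits leave unreadable from compound 1 to compound 3 is unreadable. Compound 4 carries a chlorophenyl, but through a carbamoylmethyl link rather than directly on the nitrogen, so it resembles both compound 2 and the chain-linked compound 1. Compound 4 is therefore expected to give a number near or modestly below the limit, estimated at 70000 nM with a range of 20000 nM to 200000 nM. This estimate means a step of an at least 2.1-fold lower number from compound 3 to compound 4 (0.33 log units; beyond the scatter) that may well remain unreadable.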

Compound 4, half-maximal inhibitory concentration: 12300 nM
Compound 4: middle estimate off by 5.7-fold (0.76 log units), on the high side; measured number outside the range, below it.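

On this aromatic nitrogen in this assay, ((3-chlorophenyl)carbamoyl)methyl gives a readable value where 3-(trifluoromethyl)phenyl gave none, with an at least 12-fold lower number from compound 3 to compound 4 (1.08 log units; beyond the scatter), so the aromatic ring need not sit directly on the nitrogen for a number to appear. The same group stands level with 3-chloro-4-fluorophenyl, with a 1.8-fold lower number from compound 2 to compound 4 (0.27 log units; within the scatter), so these two chlorine-bearing groups cannot be told apart in this assay. The comparison with the octyl chain gives an at least 12-fold lower number from compound 1 to compound 4 (1.08 log units; beyond the scatter), which shows that a carbon attached to this nitrogen is compatible with a readable value when it carries (3-chlorophenyl)carbamoyl rather than continuing as heptyl.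

From the compounds shown here alone, it remains open whether the chlorine in compound 4 is needed, and whether a fluorine, a methoxy group or a carboxylic acid on that phenyl ring, or a longer chain between the amide and the nitrogen, would give a similar value. How far compound 1 and compound 3 lie from the others also remains open, as their values are limits and not numbers: the limit of > 150000 nM in this assay, at which 2 of the 4 values shown sit.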